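The compounds below may be only part of what the source reports. "The series", "measured", "known", "first", "only" and "open" are said of these compounds alone.

Measured compounds in a functional assay on DU-145 cells (Homo sapiens) for cytotoxicity, read by sulforhodamine B assay, with a stated time of 2 days, tested at 100 uM; a higher number here means more inhibition at the concentration tested (going by the name of the read-out), a lower number less inhibition:

Compound 1 `O=C(Nn1c(-c2cccc([N+](=O)[O-])c2)nc2c(-c3ccc(Cl)cc3)n[nH]c2c1=O)c1cccnc1` gives 31%.
Compound 2 `CCCc1n[nH]c2c(=O)n(NC(=O)c3ccccc3)c(-c3cccc([N+](=O)[O-])c3)nc12` gives 27.8%.
Compound 3 `CCCc1n[nH]c2c(=O)n(NC(=O)c3ccccc3)c(-c3cccc(OC)c3)nc12` gives 23.6%.

Compound 2 stands second highest of the three numbers in this assay; its nearest neighbour is compound 1, which gives a number a little higher, and its furthest is compound 3, which gives a number a little lower, both gaps lying within the usual scatter. Going by the values given here, the only step between measured compounds that differ in one place is a number 4.2 percentage points lower from compound 2 to compound 3 (within the scatter), which concerns the methoxy-for-nitro exchange and stays within the scatter.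

Compound 4 `O=C(Nn1c(-c2cccc([N+](=O)[O-])c2)nc2c(-c3ccc(Cl)cc3)n[nH]c2c1=O)c1ccccc1` has not been measured. Relative to compound 2 the change is 4-chlorophenyl in place of propyl on an aromatic carbon. Among the compounds with values here, no measured step bears directly on this exchange. Compound 1 already carries the 4-chlorophenyl group on the shared core and gives 31%, a number within the scatter of compound 2, which gives 27.8%. The step from compound 2 to compound 4 is therefore expected to be small, a number 2.2 percentage points higher from compound 2 to compound 4 (within the scatter), with no direction beyond the scatter. Compound 4 is estimated at 30%, between 18% and 42%.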

Compound 4, a percentage reported as inhibition, at one concentration (the size of the read-out at that concentration, not a potency): 94.3%
Beside the measured number, compound 4's estimate is 64.3 percentage points below it; the whole stated range lies below it.
By their numbers in this assay, from the lowest: compounds 3, 2 and 1 (each within the scatter of the next); then compound 4.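

In this assay the exchange of propyl for 4-chlorophenyl, on the aromatic carbon of the five-membered ring, comes with a number 66.5 percentage points higher from compound 2 to compound 4 (beyond the scatter) and shows that this position can move the read-out strongly when phenyl sits on the carbonyl carbon. With 4-chlorophenyl held in place, the exchange of pyridin-3-yl for phenyl on that carbonyl carbon comes with a number 63.3 percentage points higher from compound 1 to compound 4 (beyond the scatter) and shows that 4-chlorophenyl does not give a high number with every carbonyl group, so among these compounds the high number appears only where the two groups occur together. Nothing measured here explains either step.

The compounds shown leave open whether an unsubstituted phenyl or a longer alkyl chain at this position would give a similar number. They also leave open whether the step would persist with methoxy in place of nitro.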